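Cyclopropyl for methylsulfonylphenyl: cytotoxicity outlook

The source may report more compounds than this note shows. Statements on the series, on what has been measured and on what is new or still open speak of the compounds shown alone.

Compound 1 `CS(=O)(=O)c1ccc(-n2c(=O)n(Cc3cc4cc(Cl)ccc4n3CCCC#N)c3cnccc32)cc1` in an ADME assay on HeLa cells (Homo sapiens) for cytotoxicity, read by ATP content, with a stated time of 3 days (a lower number here means that less compound is tolerated, a higher number that more compound is tolerated), gives > 50000 nM, which is a limit of the assay and not a number.
Compound 2 `CC(C)CCn1c(Cn2c(=O)n(C3CC3)c3ccncc32)nc2nc(Cl)ccc21` in this assay gives > 50000 nM, again a limit.
Compound 3 `O=c1n(Cc2nc3cnccc3n2CCCCO)c2cnccc2n1C1CC1` in this assay gives > 100000 nM, also a limit.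

Of the compounds shown here, three have been tested in this assay so far, and none of them returned a number: every reading is a limit. Compound 1 therefore stands only at a limit, and the two further values shown are limits as well. Two of the three readings sit at the limit of > 50000 nM in this assay, at which 2 of the 3 values shown sit, and one reading sits at the limit of > 100000 nM in this assay, at which 1 of the 3 values shown sits. Going by the values given here, with no measured step between compounds that differ in a single place, there is nothing yet that shows whether any structural change moves this read-out at all.

Compound 4 `N#CCCCn1c(Cn2c(=O)n(C3CC3)c3ccncc32)cc2cc(Cl)ccc21` is the next compound to be measured. It differs from compound 1 in one place: cyclopropyl in place of 4-(methylsulfonyl)phenyl on an aromatic nitrogen. Since every reading so far is a limit, the expectation for this change is no step beyond the scatter, with compound 4 most likely returning a limit once more. Compound 4 is therefore expected to give about 60000 nM in this assay, within a range of 30000 nM to 150000 nM. The expected step that the limit leaves unreadable from compound 1 to compound 4 is essentially none.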

Compound 4, half-maximal cytotoxic concentration: > 50000 nM
Compound 4: no number, only a limit; the forecaster's own chance of this, stated with the estimate: 80%; the middle value does not contradict the limit.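

In this assay compound 4 gives > 50000 nM, which is a limit and not a number. Compound 1 also stands only at a limit, so no step can be read for cyclopropyl in place of 4-(methylsulfonyl)phenyl between compound 1 and compound 4. The compounds shown leave open whether any single structural change moves this read-out at all, with most readings sitting at one ceiling: the limit of > 50000 nM in this assay, at which 3 of the 4 values shown sit.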